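Moving the Chlorine Around a Phenyl Ring

The compounds below may be only part of what the source reports. "The series", "measured", "known", "first", "only" and "open" are said of these compounds alone.

In a functional assay on cells (T-cell line, Homo sapiens) for inhibition (a lower number here means a stronger inhibitor, a higher number a weaker inhibitor), compound 1 `COc1ccc(CCCN2CCC(COCC3CCCCC3)CC2)cc1` gives 3000 nM, while compound 2 `Clc1ccc(CCCN2CCC(COC(c3ccccc3)c3ccccc3)CC2)cc1` gives 500 nM, the lower number of the two and a gap beyond the scatter. Compound 3 `Clc1ccccc1CCCN1CCC(COC(c2ccccc2)c2ccccc2)CC1` differs from compound 2 in one place, with 2-chlorophenyl in place of 4-chlorophenyl on a saturated chain carbon, three bonds along the chain from an amine nitrogen in a ring. The two measured compounds do not isolate a change of this kind, so any forecast is loose. No shift beyond the scatter is expected, with an estimated 1.2-fold higher number from compound 2 to compound 3 (0.08 log units; within the scatter). The estimated value for compound 3 is 600 nM, with an expected range from 200 nM to 1800 nM.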

Compound 3, half-maximal inhibitory concentration: 800 nM
Compound 3: the middle estimate sits 1.3-fold (0.12 log units) below what was measured; low and high end bracket the measured number.
By their numbers in this assay, from the lowest: compounds 2 and 3 (each within the scatter of the next); then compound 1.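

In this assay, 2-chlorophenyl in place of 4-chlorophenyl gives a 1.6-fold higher number from compound 2 to compound 3 (0.20 log units; within the scatter) and so stays within the usual scatter of repeated measurements. At this position on the chain, the two chlorophenyl groups therefore cannot be told apart by this read-out. No supporting measurement is available to explain this result.

Going by these compounds, it remains open whether a bromine atom, a methyl group or a plain phenyl ring would read the same here. On these data alone, it is also open whether a longer chain would keep compound 3 within the scatter of compound 2.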